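Trimming a phenoxy tail: from compound 1 to compound 3

The source may report more compounds than this note shows. Statements on the series, on what has been measured and on what is new or still open speak of the compounds shown alone.

Compound 1 `CCc1nc2ccccc2n1CCCOc1ccccc1` was tested in an ADME assay on Vero cells (Chlorocebus sabaeus) for cytotoxicity, read by luminescence, with a stated time of 2 days (a higher number here means that more compound is tolerated, a lower number that less compound is tolerated), and returned only a limit of > 50 uM rather than a number. Compound 2 `Cc1ccc2nc(C(C)O)n(CCCCOc3ccc(C)c(Cl)c3)c2c1` gives 8.6 uM in this assay. Of compound 1 one can therefore say only that it sits at the limit of > 50 uM in this assay, at which 1 of the 2 values shown sits, so its true place relative to compound 2 is open. Compound 3 `CCc1nc2ccccc2n1CCCCOC` is the unmeasured partner of compound 1 and differs from it by methoxymethyl in place of phenoxy on a saturated chain carbon, three bonds along the chain from an aromatic nitrogen. Among the compounds with values here, no measured pair shows a change of this kind, and the limit for compound 1 leaves no number from which a step could be sized. The expected step is a step that the limit leaves unreadable from compound 1 to compound 3, within the scatter of this assay or toward a higher number. Compound 3 is expected to give 60 uM, with a range of 30 uM to 150 uM, and most probably once more only a limit.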

Compound 3, half-maximal toxic concentration: > 50 uM
Compound 3: a limit, no number; the forecaster's own chance of this, stated with the estimate: 85%; the middle value does not contradict the limit.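

In this assay, within the data shown here, compound 1 and compound 3 both return only a limit, so no step between them can be read: the limit of > 50 uM in this assay, at which 2 of the 3 values shown sit.
The compounds shown leave open how far either compound lies past that limit, and so whether methoxymethyl in place of phenoxy changes the result at all.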